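Dodecyl in place of hydrogen on compound 3

This account rests on a few compounds, and the source may have more. Where it says the series, first, only, none or still open, it means among the compounds named here.

Measured in a functional assay on the whole organism with Mus musculus as the target, in the rotarod test; on this read-out higher numbers stand for an effect only at larger amounts of compound and lower numbers for an effect already at smaller amounts:
compound 1 `CCCCCC(=O)NCC(=O)N(C)c1ccc(Cl)cc1C(=O)c1ccccc1Cl` gives 90 mg/kg
compound 2 `CCCCCCC(=O)NCC(=O)N(C)c1ccc(Cl)cc1C(=O)c1ccccc1Cl` gives 70 mg/kg
compound 3 `CCCC(=O)NCC(=O)N(C)c1ccc(Cl)cc1C(=O)c1ccccc1Cl` gives 55.2 mg/kg

Compound 3 stands within the scatter of both other compounds, as a 1.6-fold lower number from compound 1 to compound 3 (0.21 log units; within the scatter) and a 1.3-fold lower number from compound 2 to compound 3 (0.10 log units; within the scatter) show. The third measured step, a 1.3-fold lower number from compound 1 to compound 2 (0.11 log units; within the scatter), also stays within the scatter, so the three values show no trend with chain length.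

The next compound is compound 4 `CCCCCCCCCCCCCCCC(=O)NCC(=O)N(C)c1ccc(Cl)cc1C(=O)c1ccccc1Cl`, and the change is dodecyl in place of hydrogen on a saturated chain carbon, three bonds along the chain from a carbonyl carbon in the structure. The two steps ending at compound 3 bear most directly on this change, since each replaces a group by hydrogen at that same place, but only with ethyl and propyl. For the measured compounds named here, the dodecyl group is much longer than either, and no measured compound carries a chain of that length, so the estimate is an extrapolation and its range is wide. With no measured step beyond the scatter, no step beyond the scatter is expected, though a drift towards a higher number would not surprise. The expected step is a 1.5-fold higher number from compound 3 to compound 4 (0.19 log units; within the scatter) in this assay as an estimate. For compound 4 the estimated value is 85 mg/kg, with an expected range from 30 mg/kg to 250 mg/kg overall.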

Compound 4, dose for half-maximal effect: > 100 mg/kg
Compound 4: only a limit was reported (the forecaster's own chance of this, stated with the estimate: 25%); middle value at least 1.1-fold (0.07 log units) away from the limit.
By their numbers in this assay, from the lowest: compounds 3, 2 and 1 (each within the scatter of the next). At a limit, above all of these: compound 4.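

In this assay compound 4, with dodecyl in place of hydrogen on a saturated chain carbon, three bonds along the chain from a carbonyl carbon, gives only a limit of the assay and no number: the limit of > 100 mg/kg in this assay, at which 1 of the 4 values shown sits.

Read against the shorter chains, that limit gives only floors: an at least 1.8-fold higher number from compound 3 to compound 4 (0.25 log units; that floor lies within the scatter), an at least 1.4-fold higher number from compound 2 to compound 4 (0.15 log units; that floor lies within the scatter) and an at least 1.1-fold higher number from compound 1 to compound 4 (0.04 log units; that floor lies within the scatter). Each floor lies within the scatter, so compound 4 cannot be placed beyond the scatter of any earlier compound, although its true distance from them may be larger. What is new is that compounds 1, 2 and 3 all gave numbers showing no trend with chain length, whereas this much longer chain gives none, so that lack of a trend cannot be carried out to dodecyl at this place.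

Going by these compounds, how far the true value of compound 4 lies past its limit remains open, and a single limit cannot show whether any trend with chain length exists. Also open, on these data alone, is how an octyl chain at this same place, or a shorter chain carrying an amine or a carboxylic acid, would behave in this assay.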